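Glucagon receptor binding: replacing 4-chlorophenyl with 2,3-dihydro-1H-inden-5-yl

A few compounds are considered here, and "the series" means these few. Any claim that something is new, unique, unknown or untested is made for them only; others in the source may bear on it.

Of the compounds shown here, two carry numbers so far. Compound 1 `O=C(O)CCNC(=O)c1ccc(CN(c2ccc(Cl)cc2)c2nc(-c3ccc(C(F)(F)F)cc3)cs2)cc1` serves as the reference; in an assay on membranes from liver for binding affinity to Glucagon receptor (Rattus norvegicus) (on this read-out higher numbers stand for weaker inhibition and lower numbers for stronger inhibition), compound 1 gives 1400 nM. Compound 2 `O=C(O)CCNC(=O)c1ccc(CN(c2ccc(C(F)(F)F)cc2)c2nc(-c3ccc(Cl)cc3)cs2)cc1` is the second one; in this assay compound 2 gives 2700 nM. The gap between these two falls within the scatter, so neither can be called the stronger binder; compound 1 merely has the lower of the two numbers. For the measured compounds named here, no pair of measured compounds differs in a single place, so the series itself supplies no step to lean on.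

Compound 3 `O=C(O)CCNC(=O)c1ccc(CN(c2ccc3c(c2)CCC3)c2nc(-c3ccc(C(F)(F)F)cc3)cs2)cc1` differs from compound 1 in one place: 2,3-dihydro-1H-inden-5-yl in place of 4-chlorophenyl on a nitrogen on an aromatic ring. Both the leaving and the entering group carry no hydrogen-bond donors or acceptors and no net charge, and the data hold no comparison of this kind. With nothing to support a shift in either direction, the number for compound 3 is expected to stay close to that of compound 1. The step of a 1.1-fold lower number from compound 1 to compound 3 (0.03 log units; within the scatter) is therefore expected to remain within the scatter. Compound 3 is estimated at 1300 nM, with a range from 400 nM to 4500 nM.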

Compound 3, half-maximal inhibitory concentration: 5400 nM
Estimate against measurement, compound 3: 4.2-fold (0.62 log units) below, outside the stated range (above it).
By their numbers in this assay, from the lowest: compounds 1, 2 and 3 (each within the scatter of the next, the first and the last beyond it).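

For the compounds shown here, this is the first single-place step, and it shows that in this assay the group on a nitrogen on an aromatic ring is not freely interchangeable: 2,3-dihydro-1H-inden-5-yl in place of 4-chlorophenyl gives a modest loss (a 3.9-fold higher number from compound 1 to compound 3 (0.59 log units; beyond the scatter)), beyond the scatter. Both groups have no hydrogen-bond donors or acceptors and no net charge, so the number moves even though those counts stay the same; what differs is the chlorine, present only in the leaving group, and the five-membered non-aromatic ring, present only in the entering group. No measurement at hand explains the shift or separates these two differences.

Open, from the compounds shown here alone, is whether 4-methylphenyl or plain phenyl at this place would give a number nearer compound 1 or nearer compound 3, which would help separate the loss of chlorine from the added ring. Also open, going by these compounds, is whether 2-naphthyl, with an aromatic second ring in place of the non-aromatic one, would follow compound 3.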